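A few compounds are considered here, and "the series" means these few. Any claim that something is new, unique, unknown or untested is made for them only; others in the source may bear on it.

Among the measured compounds shown here, compound 3 `FC(F)(F)c1ccccc1-c1nc(NCc2ccc(-c3ccc(Cl)c(Cl)c3)cc2)c2ccccc2n1` gives 2200 nM in an assay on a protein complex for inhibition of ubiquitin carboxyl-terminal hydrolase 1/WD repeat-containing protein 48 (Homo sapiens), read by fluorescence (a lower number here means a stronger inhibitor, a higher number a weaker inhibitor), the lowest of the three numbers known so far. Compound 1 `Fc1ccc(CNc2nc(-c3ccccc3C(F)(F)F)nc3ccccc23)cc1` stands nearest with 3400 nM in this assay, a step of a 1.5-fold lower number from compound 1 to compound 3 (0.19 log units; within the scatter), while compound 2 `FC(F)(F)c1ccc(CNc2nc(-c3ccccc3C(F)(F)F)nc3ccccc23)cc1` stands furthest with 8900 nM, a step of a 4.0-fold lower number from compound 2 to compound 3 (0.61 log units; beyond the scatter). Compound 4 `FC(F)(F)c1cc(-c2ccc(CNc3nc(-c4ccccc4C(F)(F)F)nc4ccccc34)cc2)ccn1` arises from compound 3 by the change (2-(trifluoromethyl)pyridin-4-yl in place of 3,4-dichlorophenyl on an aromatic carbon). For the measured compounds named here, no measured step exchanges one such ring for another; the two steps that bear on it, a 1.5-fold lower number from compound 1 to compound 3 (0.19 log units; within the scatter) and a 4.0-fold lower number from compound 2 to compound 3 (0.61 log units; beyond the scatter), show that carrying a second ring on that aromatic carbon gave numbers close to or lower than the small groups. The step is therefore expected to be small, a 1.1-fold higher number from compound 3 to compound 4 (0.06 log units; within the scatter), in this assay. Compound 4 is thus estimated at 2500 nM, with a range from 900 nM to 7000 nM.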

Compound 4, half-maximal inhibitory concentration: 4900 nM
Estimate against measurement, compound 4: 2.0-fold (0.29 log units) below, and the stated range covers the measured number.
By their numbers in this assay, from the lowest: compounds 3, 1, 4 and 2 (each within the scatter of the next, the first and the last beyond it).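

In this assay the exchange of one ring for another at this position is not silent, giving a 2.2-fold higher number from compound 3 to compound 4 (0.35 log units; beyond the scatter). Against the small groups the new ring gives a 1.8-fold lower number from compound 2 to compound 4 (0.26 log units; within the scatter) and a 1.4-fold higher number from compound 1 to compound 4 (0.16 log units; within the scatter), so the clear gain over trifluoromethyl seen with 3,4-dichlorophenyl does not hold for every second ring. Nothing available explains the difference between the two rings. Open, as far as these compounds go, is where an unsubstituted phenyl, or a ring carrying an amine or a carboxylic acid, would fall at this position.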